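This account rests on a few compounds, and the source may have more. Where it says the series, first, only, none or still open, it means among the compounds named here.

Measured in an ADME assay for permeability, using PAMPA, at pH 7.4; a higher number here means that the compound crosses the layer faster, a lower number that the compound crosses the layer more slowly:
- compound 1 `CN(C[C@H]1Cc2c(cccc2N2CCN3CCC[C@H]3C2)CN1)[C@H]1CCCc2cccnc21`: 167 nm/s
- compound 2 `CCN(C[C@H]1Cc2c(cccc2N2CCNCC2)CN1)[C@H]1CCCc2cccnc21`: 75 nm/s

Compound 1 stands highest of the two at 167 nm/s. Compound 2 gives 75 nm/s, and this gap lies beyond the scatter.

Compound 3 `CCN1CCN(c2cccc3c2C[C@H](CN(C)[C@H]2CCCc4cccnc42)NC3)CC1` has not yet been measured in this assay. It keeps the core of compound 1 and changes one group, on an aromatic carbon of a six-membered aromatic ring of carbon only: a group of 8 heavy atoms (6 carbon, 2 nitrogen; one six-membered non-aromatic ring with 2 hetero atoms) in place of a group of 9 heavy atoms (7 carbon, 2 nitrogen; one five-membered non-aromatic ring with 1 hetero atom, one six-membered non-aromatic ring with 2 hetero atoms), on an aromatic carbon. The entering 4-ethylpiperazin-1-yl group has one six-membered non-aromatic ring with 2 hetero atoms, and the five-membered non-aromatic ring of the leaving group is gone.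

Among the compounds with values here, no two measured compounds differ in one place only, so the data give no direct measure of such a change. Only a small downward move is expected, with no change beyond the scatter as the likeliest outcome. The expected size is a 1.2-fold lower number from compound 1 to compound 3 (0.08 log units; within the scatter), an estimate that rests on this single structural change. For compound 3 the estimated value is 140 nm/s, with an expected range of 70 nm/s to 280 nm/s.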

Compound 3, apparent permeability: 205 nm/s
Beside the measured number, compound 3's estimate is 1.5-fold (0.17 log units) below it, and the stated range covers the measured number.
By their numbers in this assay, from the lowest: compound 2; then compounds 1 and 3 (each within the scatter of the next).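

In this assay, within the data shown here, setting the 4-ethylpiperazin-1-yl group in place of the group with one five-membered and one six-membered non-aromatic ring gives a 1.2-fold higher number from compound 1 to compound 3 (0.09 log units; within the scatter) and is the only single-place step available. At this aromatic carbon of the six-membered aromatic ring of carbon only, removing the five-membered non-aromatic ring and the defined stereocentre of the leaving group, with the counts of hydrogen-bond donors and acceptors unchanged, therefore leaves the read-out within the scatter. No measurement at hand accounts for this outcome.

Compound 2 differs from compound 1 and from compound 3 in more than one place, so the steps to it cannot be read, and the separate contributions of its unsubstituted piperazine and its ethyl group on the chain nitrogen remain unresolved. From the compounds shown here alone, it also remains open whether this tolerance extends beyond these two ring-bearing groups at the same aromatic carbon, for example to a morpholin-4-yl group, an open-chain dimethylamino group or a carboxylic acid.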